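The source may hold more compounds than are shown below. What is called first, only, known or untested is meant among the compounds shown, and "the series" means these compounds.

Of the compounds shown here, two of a shared core have been measured in a functional assay on HCT-116 cells (Homo sapiens) for antiproliferative activity, read by MTT assay, with a stated time of 72 h; a higher number here means a weaker inhibitor, a lower number a stronger inhibitor. Compound 1 `NC1=NC2(CCSCC2)N(OCCCOc2cccc(Cl)c2)C(N)=N1` gives 1 nM in this assay, while compound 2 `NC1=NC2(CCOCC2)N(OCCCOc2ccc(F)cc2)C(N)=N1` gives 3280 nM. Among these two numbers compound 2 stands highest, and the gap to compound 1 lies far beyond the scatter; the two compounds differ in more than one place, so the numbers alone show no single cause.

Compound 3 `NC1=NC2(CCOCC2)N(OCCCOc2cccc(Cl)c2Cl)C(N)=N1` has not yet been measured in this assay. It differs from compound 2 at one place: 2,3-dichlorophenyl in place of 4-fluorophenyl on an oxygen on a saturated carbon. Among the compounds with values here, no measured pair of compounds isolates this change, so the size of the step can only be anticipated. Given that compound 1, the only compound with a chlorine on its aromatic ring, gives 1 nM, compound 3 is expected to move to a lower number, by an estimated 22-fold lower number from compound 2 to compound 3 (1.34 log units; beyond the scatter). In this assay compound 3 is estimated at 150 nM, within a range from 10 nM to 2000 nM.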

Compound 3, half-maximal inhibitory concentration: 5 nM
For compound 3 the middle estimate is 30-fold (1.48 log units) above the measured one; the whole stated range lies above it.
By their numbers in this assay, from the lowest: compound 1; then compound 3; then compound 2.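

With compound 2 and compound 3, the shared core gains its first step that isolates a single place: in this assay, 2,3-dichlorophenyl in place of 4-fluorophenyl on an oxygen on a saturated carbon gives a 660-fold lower number from compound 2 to compound 3 (2.82 log units; beyond the scatter) and this step is large. The rest of the molecule stays the same across this pair, so this position is far from indifferent to which substituted phenyl group it carries. Nothing in the data given accounts for the size of this step.

This single step replaces one fluorine with two chlorines, so it leaves open whether one chlorine alone would produce a similar shift and whether the position of the chlorine matters. It also leaves open how a phenyl ring carrying a methoxy group, an amine or a carboxylic acid would read in this assay at this place.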